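Lipophilicity notes: pyridin-3-yl amide in place of phenyl

A few compounds are considered here, and "the series" means these few. Any claim that something is new, unique, unknown or untested is made for them only; others in the source may bear on it.

Measured compounds in a physicochemical assay for lipophilicity, read by HPLC, at pH 7.4; on this read-out lower numbers stand for lower lipophilicity and higher numbers for higher lipophilicity:
- compound 1 `NCc1csc(NC(=O)c2cc3ccccc3[nH]2)n1` gives 1.4
- compound 2 `NCc1csc(NC(=O)c2ccn[nH]2)n1` gives 0.1
- compound 3 `CC(C)(C)c1cc(C(=O)Nc2ccccc2)n(Cc2ccccc2)n1` gives 4.7

Compound 3 stands highest of the three numbers in this assay; the nearest is compound 1, lower by a gap beyond the scatter, and compound 2 lies further below it, also beyond the scatter. Compound 4 `CC(C)(C)c1cc(C(=O)Nc2cccnc2)n(Cc2ccccc2)n1` is not yet measured. It differs from compound 3 in one place: pyridin-3-yl in place of phenyl on an amide-type nitrogen. The step from compound 3 to compound 4 in this assay is expected to be a clear drop, a number 1.20 log units lower from compound 3 to compound 4 (beyond the scatter), beyond the scatter. For compound 4 the expected value in this assay is 3.5, with a range from 3 to 4.1.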

Compound 4, distribution coefficient: 3.8
For compound 4 the middle estimate is 0.30 log units below the measured one; low and high end bracket the measured number.
By their numbers in this assay, from the lowest: compound 2; then compound 1; then compound 4; then compound 3.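

In this assay, among these compounds, the change to pyridin-3-yl on an amide-type nitrogen gives a number 0.90 log units lower from compound 3 to compound 4 (beyond the scatter) as a modest step, the only one-place comparison so far. With the heavy-atom count unchanged, pyridin-3-yl carries 1 hydrogen-bond acceptor where phenyl carries 0, so this position responds to a change of one ring atom. No measurement here explains the step.

Going by these compounds, whether pyridin-2-yl or pyridin-4-yl at the same place gives a step of similar size remains open. So does whether the step carries over to the core of compound 1.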